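A few compounds are considered here, and "the series" means these few. Any claim that something is new, unique, unknown or untested is made for them only; others in the source may bear on it.

Measured so far:
- compound 1, `CC1N=C(S)N(Nc2ccccc2)C1C`, in a functional assay on MT4 cells (Homo sapiens) for cytotoxicity (on this read-out higher numbers stand for lower toxicity in this test and lower numbers for higher toxicity in this test), compound 1 gives 181000 nM
- compound 2, `Cc1cccc(NN2C=NC(C)C2C)c1`, in this assay compound 2 gives 312000 nM

Compound 2 has the highest of the two numbers, but its nearest neighbour, compound 1, sits within the usual scatter of it, so the two cannot be told apart on this read-out. Among the measured compounds shown here, no step between two measured compounds is available that would show how a single change of structure moves the number here.

Compound 3, `CC1N=CN(Nc2ccccc2)C1C`, has not been measured. It differs from compound 2 in one place: hydrogen in place of methyl on an aromatic carbon. This is a small change that removes one carbon from the edge of the molecule. With nothing in the measured pair pointing to a shift, the step from compound 2 to compound 3 is expected to stay within the scatter, with no direction to it. For compound 3 the expected value is 250000 nM, with a range from 110000 nM to 550000 nM. That estimate corresponds to an expected step of a 1.2-fold lower number from compound 2 to compound 3 (0.10 log units; within the scatter).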

Compound 3, half-maximal cytotoxic concentration: 351000 nM
Compound 3: middle estimate off by 1.4-fold (0.15 log units), on the low side; the measured number falls inside the stated range.
By their numbers in this assay, from the lowest: compounds 1, 2 and 3 (each within the scatter of the next).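

In this assay the change to hydrogen in place of methyl on an aromatic carbon gives a 1.1-fold higher number from compound 2 to compound 3 (0.05 log units; within the scatter) and so adds little: at this place, the methyl has no effect that can be told apart from the usual scatter. Among the compounds shown here, the first comparison at the other changed place, hydrogen in place of sulfanyl on a carbon with a double bond to nitrogen, gives a 1.9-fold higher number from compound 1 to compound 3 (0.29 log units; within the scatter) and so also stays within the scatter, though close to its edge. Nothing measured here bears on the reason for either result.

As far as these compounds go, whether an amine or a carboxylic acid on that aromatic carbon would move the number beyond the scatter remains open. The same question stands for a hydroxyl group or a longer chain such as propyl on the carbon that carries sulfanyl in compound 1.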